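The compounds below may be only part of what the source reports. "The series", "measured", "known", "first", "only" and "open" are said of these compounds alone.

Compound 1 `COc1cc(O)cc(O)c1C(=O)/C=C/c1ccc(C)cc1` gives > 50000 nM
Compound 2 `COc1cc(/C=C/C(=O)c2c(O)cc(O)cc2OC)ccc1O` gives > 50000 nM

In a functional assay on HepG2 cells (Homo sapiens) for inhibition, read by MTT assay, with a stated time of 72 h (a lower number here means a stronger inhibitor, a higher number a weaker inhibitor), compound 1 gives > 50000 nM as a limit of the assay, not a number. Compound 2 gives > 50000 nM as a limit too. Compound 1 therefore stands with compound 2 at the limit of > 50000 nM in this assay, at which 2 of the 2 values shown sit, and no exact potency is known for either.

Compound 3 `COc1cc(O)cc(O)c1C(=O)/C=C/c1ccc(C(F)(F)F)cc1` carries trifluoromethyl in place of methyl on an aromatic carbon, para to a large group, a change counted as trifluoromethyl in place of methyl on an aromatic carbon in full.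

For the measured compounds named here, no measured step is available to size this change. With compound 1 at > 50000 nM as a limit, a step within the scatter is expected in this assay, with any shift leaning towards a stronger inhibitor. The estimated move is a number no higher from compound 1 to compound 3 (the limit leaves the size open) and is expected to be small. For compound 3 the estimated value is 50000 nM, with an expected range of 18000 nM to 100000 nM.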

Compound 3, half-maximal inhibitory concentration: 14100 nM
Compound 3: the middle estimate sits 3.5-fold (0.55 log units) above what was measured, and the stated range ends above it.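

In this assay, trifluoromethyl in place of methyl on an aromatic carbon, para to a large group, gives an at least 3.5-fold lower number from compound 1 to compound 3 (0.54 log units; beyond the scatter). This shows that a single replacement at this position is enough to move the shared core off the limit of the assay, which the two earlier compounds could not show. For the compounds shown here, compound 3 is the only one of the three compounds with an exact value, and the other two share a limit: the limit of > 50000 nM in this assay, at which 2 of the 3 values shown sit.

The compounds shown leave open whether this gain is particular to trifluoromethyl or would also appear with a chlorine atom, a nitrile or a carboxylic acid at the same position. As far as these compounds go, the full size of the step also stays open, as compound 1 has only a limit and not a number.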